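Restoring an Aryl Group on the Ring Nitrogen

The compounds below may be only part of what the source reports. "The series", "measured", "known", "first", "only" and "open" are said of these compounds alone.

Compound 1 `COc1ccc(C)cc1N1C(=O)CSC1c1cccc(C(=O)NCCCCc2ccccc2)c1` gives 300 nM in a functional assay on HOS-TE85 cells (Homo sapiens) for inhibition, read by CCK-8 assay, with a stated time of 72 h; a higher number here means a weaker inhibitor, a lower number a stronger inhibitor. Compound 2 `CCN1C(=O)CSC1c1cccc(C(=O)NCCCCc2ccccc2)c1` reaches a limit of this assay, > 1000 nM, so its exact number is not known. Within the data shown here, the single measured step, an at least 3.3-fold higher number from compound 1 to compound 2 (0.52 log units; beyond the scatter), shows that swapping the aryl group for ethyl weakened inhibition, and because one value sits at the limit of > 1000 nM in this assay, at which 1 of the 2 values shown sits, the full size of that loss stays open. Compound 3 `CC(F)(F)c1cccc(N2C(=O)CSC2c2cccc(C(=O)NCCCCc3ccccc3)c2)c1` moves the other way: a group of 10 heavy atoms (8 carbon, 2 fluorine; one six-membered aromatic ring of carbon only) in place of a group of 2 heavy atoms (2 carbon; no ring), on an amide-type nitrogen in a ring. Since an at least 3.3-fold higher number from compound 1 to compound 2 (0.52 log units; beyond the scatter) ran toward weaker inhibition, the reverse direction is expected here, an at least 2.5-fold lower number from compound 2 to compound 3 (0.39 log units; beyond the scatter). Compound 3 is therefore estimated at 400 nM, within 150 nM to 1500 nM.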

Compound 3, half-maximal inhibitory concentration: 29.1 nM
Estimate against measurement, compound 3: 14-fold (1.14 log units) above; measured number below the stated range.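

At this ring nitrogen, the detail of the aryl group matters, and not only its presence: a 10-fold lower number from compound 1 to compound 3 (1.01 log units; beyond the scatter) comes with exchanging 2-methoxy-5-methylphenyl for the fluorine-bearing aryl group. Going from ethyl back to an aryl group gives an at least 34-fold lower number from compound 2 to compound 3 (1.53 log units; beyond the scatter), a far larger change than the earlier compounds revealed. Compound 2 stands at a limit, which leaves the true size of that step open: the limit of > 1000 nM in this assay, at which 1 of the 3 values shown sits. The compounds shown do not tell which part of the aryl group in compound 3 carries the gain, or how a plain phenyl, a benzyl or a pyridine ring on this nitrogen would compare.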